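The compounds below may be only part of what the source reports. "The series", "measured", "known", "first", "only" and "open" are said of these compounds alone.

Measured so far in a functional assay on BXPC-3 cells (Homo sapiens) for inhibition, read by XTT assay, with a stated time of 72 h; a higher number here means a weaker inhibitor, a lower number a stronger inhibitor:
Compound 1 `CC(C)(C)OC(=O)N1CCC[C@H]1COCCCCCCCC/C=C/c1ccc(-c2ccccc2)cc1` gives 70000 nM.
Compound 2 `CC(C)(C)OC(=O)N1CCC[C@H]1COCCCCCCCC/C=C/c1ccc(Oc2ccccc2)cc1` gives only a limit of the assay, > 100000 nM.
Compound 3 `CC(=O)N1CCC[C@H]1COCCCCCCCCC/C=C/c1ccc(-c2ccccc2)cc1` gives 56700 nM.

Compound 1 and compound 2 share a core and differ in one place: phenoxy in place of phenyl on an aromatic carbon. That change made an at least 1.4-fold higher number from compound 1 to compound 2 (0.15 log units; that floor lies within the scatter), and the step cannot be sized more closely because compound 2 sits at the limit of > 100000 nM in this assay, at which 1 of the 3 values shown sits. Compound 3 carries a different core, and the difference between the two cores is not broken down here. Compound 4 `CC(=O)N1CCC[C@H]1COCCCCCCCCC/C=C/c1ccc(Oc2ccccc2)cc1` is not yet measured; it stands to compound 3 as compound 2 stands to compound 1, with the same change in the same place: phenoxy in place of phenyl on an aromatic carbon. Beside the earlier step, the expected step is a 2.1-fold higher number from compound 3 to compound 4 (0.33 log units; beyond the scatter), resting on the earlier at least 1.4-fold higher number from compound 1 to compound 2 (0.15 log units; that floor lies within the scatter) and on compound 3 giving 56700 nM. Compound 4 is therefore estimated at 120000 nM, with a real chance that this assay again reports only a limit.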

Compound 4, half-maximal inhibitory concentration: 73300 nM
Compound 4: middle estimate off by 1.6-fold (0.21 log units), on the high side, within the range that was stated.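

In this assay putting phenoxy in place of phenyl on the core of compound 3 gave a 1.3-fold higher number from compound 3 to compound 4 (0.11 log units; within the scatter) and so does not separate the two compounds. Set beside the same change on the core of compound 1, this step shows no clear disagreement between the two cores: the same change on two cores in this assay, an at least 1.4-fold higher number (0.15 log units; that floor lies within the scatter) from compound 1 to compound 2 and a 1.3-fold higher number (0.11 log units; within the scatter) from compound 3 to compound 4; the limit leaves it open whether they differ. Compound 2 gives only a limit, > 100000 nM and this leaves no exact step on that core to compare, so it is not shown that the change carries over with the same size.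

The compounds shown leave open whether another group on that aromatic carbon, such as an amine or a carboxylic acid, would give a step beyond the scatter. They also leave open how a longer chain would act on either core.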